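The source may hold more compounds than are shown below. What is called first, only, known or untested is meant among the compounds shown, and "the series" means these compounds.

Three compounds have been measured in a functional assay on MV4-11 cells (Homo sapiens) for antiproliferative activity, read by CCK-8 assay, with a stated time of 72 h; on this read-out higher numbers stand for weaker inhibition and lower numbers for stronger inhibition:

compound 1 `COc1cccc(-c2cn(C)c(=O)c3[nH]c(C(=O)NCc4ccc(C(=O)Nc5ccccc5N)cc4)cc23)c1` gives 250 nM
compound 2 `Cn1cc(-c2ccccc2Oc2ccccc2)c2cc(C(=O)NCCCC(=O)NO)[nH]c2c1=O` gives 380 nM
compound 3 `Cn1cc(-c2ccccc2Oc2ccccc2)c2cc(C(=O)NCCCCC(=O)Nc3ccccc3N)[nH]c2c1=O` gives 240 nM

On these numbers compound 1 lies between compound 3 and compound 2, and both gaps fall within the scatter, so the three compounds cannot be separated by this read-out. Among the measured compounds shown here, the single measured step, a 1.6-fold lower number from compound 2 to compound 3 (0.20 log units; within the scatter), concerns the chain end and not the aryl group.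

Compound 4 `CC(C)Oc1ccccc1-c1cn(C)c(=O)c2[nH]c(C(=O)NCc3ccc(C(=O)Nc4ccccc4N)cc3)cc12` has not been measured. For the measured compounds named here, it differs from compound 1 in one place: 2-isopropoxyphenyl in place of 3-methoxyphenyl on an aromatic carbon No measured step touches this aryl group. The only indirect hint is that compound 1 and compounds 2 and 3 carry different aryl groups yet give numbers within the scatter of one another, which argues against a large effect. No step beyond the scatter is therefore expected in this assay for this change.

Compound 4 is estimated to give 250 nM, with a range from 100 nM to 650 nM. The expected step is no change at the digits printed from compound 1 to compound 4 (within the scatter), which would sit within the scatter.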

Compound 4, half-maximal inhibitory concentration: 130 nM
The estimate for compound 4 lay 1.9-fold (0.28 log units) above the measured number; the range from low to high includes it.
By their numbers in this assay, from the lowest: compounds 4, 3, 1 and 2 (each within the scatter of the next, the first and the last beyond it).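

In this assay, the exchange of 3-methoxyphenyl for 2-isopropoxyphenyl on this aromatic carbon gives a 1.9-fold lower number from compound 1 to compound 4 (0.28 log units; within the scatter), so this first direct test of the position shows a change of aryl group here that cannot be told apart from repeat-measurement scatter. The exchange alters both the alkoxy group and its place on the phenyl ring in a single step, so the result cannot be assigned to either alteration alone. No supporting measurement bears on why the two compounds compare as they do.

The compounds shown leave open whether a plain phenyl group at this position, or an amine or a carboxylic acid on this aryl ring, would give a step beyond the scatter. They also leave open whether the outcome of this exchange carries over to other chain ends.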